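The source may report more compounds than this note shows. Statements on the series, on what has been measured and on what is new or still open speak of the compounds shown alone.

Measured compounds in a functional assay on A549 cells (Homo sapiens) for antiproliferative activity, read by CCK-8 assay, with a stated time of 72 h; a lower number here means a stronger inhibitor, a higher number a weaker inhibitor:
compound 1, `CCc1ccc(SCc2ccc(/C=C/C(=O)Nc3ccccc3N)cc2)cc1`: 1300 nM
compound 2, `CCc1ccc(SCc2ccc(C(=O)Nc3ccccc3N)cc2)cc1`: 3040 nM
compound 3, `Cc1ccc(SCc2ccc(C(=O)Nc3ccccc3N)cc2)cc1`: 3270 nM

Compound 1 stands with the lowest number of the three in this assay; compound 2 and compound 3 both show higher numbers that lie beyond the scatter. Compound 2 and compound 3 differ in one place, and the step of a 1.1-fold higher number from compound 2 to compound 3 (0.03 log units; within the scatter) is small and within the scatter.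

Compound 4, `Nc1ccccc1NC(=O)/C=C/c1ccc(CSCCc2ccccc2)cc1`, has not been measured in this assay. It keeps the core of compound 1 and differs from it only in one place: phenethyl in place of 4-ethylphenyl on a sulfur.

Among the measured compounds shown here, no measured step touches the group on the sulfur. For the measured compounds named here, the only measured step, a 1.1-fold higher number from compound 2 to compound 3 (0.03 log units; within the scatter), concerns a different part of the molecule and was within the scatter, so it gives no guidance on direction or size here. The expectation for compound 4 therefore rests on compound 1 alone, with a wide range. The step of a 1.4-fold higher number from compound 1 to compound 4 (0.14 log units; within the scatter) is expected to be small and uncertain. For compound 4 in this assay the estimate is 1800 nM, within 600 nM to 6000 nM.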

Compound 4, half-maximal inhibitory concentration: 1150 nM
For compound 4 the middle estimate is 1.6-fold (0.19 log units) above the measured one; the range from low to high includes it.
By their numbers in this assay, from the lowest: compounds 4 and 1 (each within the scatter of the next); then compounds 2 and 3 (each within the scatter of the next).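

In this assay, the step of a 1.1-fold lower number from compound 1 to compound 4 (0.05 log units; within the scatter) lies within the scatter, so 4-ethylphenyl and phenethyl on this sulfur cannot be told apart. Among the compounds shown here, this is the first measured change at the sulfur, and it shows that the same eight carbons, with their one aromatic ring, can be joined differently here and leave the antiproliferative reading of the core of compound 1 intact. Nothing available explains why the two groups read alike.

The compounds shown leave open whether the group on the sulfur needs an aromatic ring at all, which a cyclohexyl group or a longer chain would test, and whether a phenethyl carrying an amine or a carboxylic acid would read the same. On these data alone, it also remains open whether phenethyl would match 4-ethylphenyl on the core of compound 2.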